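The source may report more compounds than this note shows. Statements on the series, on what has been measured and on what is new or still open speak of the compounds shown alone.

Compound 1 `COc1cc2ncnc(Nc3ccc(B(O)O)cc3)c2cc1OC` — 49%
Compound 2 `COCCOc1cc2ncnc(Nc3ccc(B(O)O)cc3)c2cc1OCCOC` — 41%
Compound 3 `COc1cc2ncnc(Nc3cccc(Cl)c3)c2cc1B(O)O` — "not active" (no number reported)

In an assay on isolated protein for inhibition of vascular endothelial growth factor receptor 1 (Homo sapiens), read by ELISA, with a stated time of 20 min, tested at 1 uM (on this read-out higher numbers stand for more inhibition at the one concentration tested (going by the name of the read-out) and lower numbers for less inhibition), compound 1 gives 49%, the higher of the two numbers reported. Compound 2 gives 41%, which lies within the usual scatter of the number for compound 1, so the two cannot be told apart. Compound 3 is recorded as not active in this assay, without a number. No pair among these three differs in only one place, so no measured step is available.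

Compound 4 `COC(=O)c1ccc(Nc2ncnc3cc(OC)c(OC)cc23)cc1` is not yet measured. Going by the values given here, it differs from compound 1 in one place: a group of 4 heavy atoms (2 carbon, 2 oxygen; no ring) in place of a group of 3 heavy atoms (1 boron, 2 oxygen; no ring), on an aromatic carbon The data hold no step that resembles this exchange, so its effect has to be guessed. He expects the step of a number 14 percentage points lower from compound 1 to compound 4 (beyond the scatter) to be a modest loss, of a size that may not clear the scatter. Compound 4 is therefore estimated at 35%, with a range from 10% to 60%.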

Compound 4, a percentage reported as inhibition, at one concentration (the size of the read-out at that concentration, not a potency): "not active" (no number reported)
No number was reported for compound 4, and the estimate cannot be compared.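

Compound 4 is recorded as not active, without a number, so no step from compound 1 can be read, and no measurement shown bears on this result. The compounds shown leave open how other groups at this place would compare with compound 1.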